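Swapping Chloro for Sulfamoyl on a Shared Core

The compounds below may be only part of what the source reports. "The series", "measured", "known", "first", "only" and "open" are said of these compounds alone.

Compound 1, `N#CC1=C(N)Oc2c(c3nc4ccccc4nc3c3ccccc23)C12C(=O)N(Cc1cnnn1-c1cccc(Cl)c1)c1ccccc12`, gives 35200 nM in an ADME assay on L02 cells (Homo sapiens) for antiproliferative activity, read by MTT assay, with a stated time of 48 h; on this read-out lower numbers stand for stronger inhibition and higher numbers for weaker inhibition.
Compound 2, `CCOc1ccccc1-n1nncc1CN1C(=O)C2(C(C#N)=C(N)Oc3c2c2nc4ccccc4nc2c2ccccc32)c2ccccc21`, reaches only the limit > 50000 nM in this assay.

Within the data shown here, compound 1 holds the only actual number in this assay; the other value is a limit of the assay rather than a number. Among the measured compounds shown here, the one measured step, an at least 1.4-fold higher number from compound 1 to compound 2 (0.15 log units; that floor lies within the scatter), changes the group on the aromatic nitrogen and is described by the limit of > 50000 nM in this assay, at which 1 of the 2 values shown sits, so its true size is unknown beyond its floor, which lies within the scatter.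

Compound 3, `N#CC1=C(N)Oc2c(c3nc4ccccc4nc3c3ccccc23)C12C(=O)N(Cc1cnnn1-c1cccc(S(N)(=O)=O)c1)c1ccccc12`, differs from compound 1 by sulfamoyl in place of chloro on an aromatic carbon. For the measured compounds named here, no measured step exchanges chloro for sulfamoyl, so the only guide is that the one change to this aryl group, an at least 1.4-fold higher number from compound 1 to compound 2 (0.15 log units; that floor lies within the scatter), did not show a step beyond the scatter. The step in this assay is therefore expected to be small, with no clear direction, and a limit is quite possible.

Compound 3 is estimated at 40000 nM, within 15000 nM to 100000 nM, meaning an expected step of a 1.1-fold higher number from compound 1 to compound 3 (0.06 log units; within the scatter).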

Compound 3, half-maximal inhibitory concentration: > 50000 nM
Compound 3: only a limit was reported (the forecaster's own chance of this, stated with the estimate: 40%); at least 1.2-fold (0.09 log units) between middle value and limit.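

In this assay, compound 3 gives only a limit of the assay, > 50000 nM, and not a number. Sulfamoyl in place of chloro on this aromatic carbon shows an at least 1.4-fold higher number from compound 1 to compound 3 (0.15 log units; that floor lies within the scatter), so this second change to the aryl group, like the first, shows no step beyond the scatter, and its true size is unknown beyond that floor. The step between compound 2 and compound 3 cannot be read, and compound 1 remains the only compound with a number to compare: the limit of > 50000 nM in this assay, at which 2 of the 3 values shown sit.

On these data alone, it remains open whether any group at this place gives a number clearly lower than that of compound 1, for example an amine or a carboxylic acid in place of the chloro. Also open, as far as these compounds go, is how far compound 2 and compound 3 truly lie from compound 1, and from each other.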